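This account rests on a few compounds, and the source may have more. Where it says the series, first, only, none or still open, it means among the compounds named here.

Compound 1 `Cc1cccc(NC(=O)[C@@H]2CCCN2S(=O)(=O)c2cccc3cccnc23)c1`, compound 2 `O=C(Nc1ccc(Cl)cc1Cl)[C@@H]1CCCN1S(=O)(=O)c1cccc2cccnc12` and compound 3 `Cc1ccc(Cl)c(NC(=O)[C@@H]2CCCN2S(=O)(=O)c2cccc3cccnc23)c1` share one core. In an ADME assay on HEp-2 cells (Homo sapiens) for cytotoxicity (on this read-out higher numbers stand for lower toxicity in this test and lower numbers for higher toxicity in this test), compound 1 gives 25500 nM. Compound 2 gives > 50000 nM, which is a limit of the assay and not a number. For the measured compounds named here, the only measured step, an at least 1.9-fold higher number from compound 1 to compound 2 (0.29 log units; that floor lies within the scatter), has a floor within the scatter. Compound 3 differs from compound 2 on an amide-type nitrogen: 2-chloro-5-methylphenyl in place of 2,4-dichlorophenyl on an amide-type nitrogen. Going by the values given here, with only that step to go on, no change beyond the scatter is expected in this assay. The estimated step is an at least 1.2-fold lower number from compound 2 to compound 3 (0.09 log units; that floor lies within the scatter). For compound 3 the estimate is 40000 nM, with an expected range from 18000 nM to 70000 nM.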

Compound 3, half-maximal cytotoxic concentration: > 50000 nM
Compound 3 gave a limit, no number; the forecaster's own chance of this, stated with the estimate: 45%; at least 1.2-fold (0.09 log units) between middle value and limit.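

In this assay compound 3 gives a limit of the assay and not a number, so the step from 2,4-dichlorophenyl to 2-chloro-5-methylphenyl on the amide-type nitrogen cannot be read. Chloro in place of hydrogen on an aromatic carbon gives an at least 1.9-fold higher number from compound 1 to compound 3 (0.29 log units; that floor lies within the scatter). A second change on this amide-type nitrogen has thus ended at the same limit, and most of the series now sits there: the limit of > 50000 nM in this assay, at which 2 of the 3 values shown sit.

On these data alone, whether compound 2 and compound 3 truly differ stays open. So does how an aryl group carrying an amine or a carboxylic acid would read on this nitrogen.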